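Bromo in Place of Chloro: Half-Life Expected to Hold

The source may report more compounds than this note shows. Statements on the series, on what has been measured and on what is new or still open speak of the compounds shown alone.

Three compounds have been measured in a physicochemical assay for pharmacokinetics, read by LC-MS, in phosphate buffer, at pH 7.4, in the presence of a further agent that is not named here; on this read-out higher numbers stand for a longer-lived compound and lower numbers for a shorter-lived compound:

Compound 1 `C=CC(=O)N1CC(NC(=O)Cn2c(C)c(C(=O)N3CCc4c(cccc4OC)C3)c3cc(Br)cc(C)c32)C1` gives 1.67 h.
Compound 2 `C=CC(=O)N1CC(NC(=O)Cn2cc(C(=O)N(C)Cc3ccccc3)c3cc(Br)ccc32)C1` gives 1.67 h.
Compound 3 `C=CC(=O)N1CC(NC(=O)Cn2c(C)c(C(=O)N3CCc4c(cccc4OC)C3)c3cc(Cl)ccc32)C1` gives 1.67 h.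

In this assay compound 3 stands level with compound 1 and compound 2 at the digits printed; the three values lie within the usual scatter of one another, so no order among them can be read. Compound 4 `C=CC(=O)N1CC(NC(=O)Cn2c(C)c(C(=O)N3CCc4c(cccc4OC)C3)c3cc(Br)ccc32)C1` has not yet been measured. It differs from compound 3 by a single exchange: bromo in place of chloro on an aromatic carbon. Going by the values given here, no pair of measured compounds shows this exchange, so there is no measured step to lean on. Given that compound 3 gives 1.67 h, the step from compound 3 to compound 4 in this assay is expected to be no change at the digits printed from compound 3 to compound 4 (within the scatter), nothing beyond the scatter. Compound 4 is therefore estimated at 1.67 h, with a range from 0.9 h to 3.1 h.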

Compound 4, half-life: 1.67 h
Estimate against measurement, compound 4: no gap at the digits printed; low and high end bracket the measured number.
By their numbers in this assay, from the lowest: compounds 1, 2, 3 and 4 (each within the scatter of the next).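

In this assay, going by these compounds alone, bromo in place of chloro on this aromatic carbon, meta to a fused ring and para to a fused ring, gives no change at the digits printed from compound 3 to compound 4 (within the scatter), the first reading of this exchange. Hydrogen in place of methyl on an aromatic carbon gives no change at the digits printed from compound 1 to compound 4 (within the scatter), so neither exchange separates these compounds on this read-out. Nothing available here accounts for either result. The compounds shown leave open how an amine or a carboxylic acid at the chloro and bromo position would read in this assay. They also leave open whether a longer chain in place of the methyl would read the same.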